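Replacing the 4-fluorophenyl group of compound 3

The compounds below may be only part of what the source reports. "The series", "measured", "known", "first", "only" and "open" are said of these compounds alone.

In a functional assay on SGC-7901 cells (Homo sapiens) for antiproliferative activity, read by MTT assay, with a stated time of 24 h (a higher number here means a weaker inhibitor, a lower number a stronger inhibitor), compound 1 (`O=C(NNc1cccc(Cl)c1)c1ccc(NS(=O)(=O)c2cnc(O)nc2O)cc1`) gives 11600 nM as its half-maximal inhibitory concentration, and compound 2 (`O=C(NNc1ccccc1Cl)c1cccc(NS(=O)(=O)c2cnc(O)nc2O)c1`) gives 2270 nM on the same read-out. Compound 3 (`O=C(NNc1ccc(F)cc1)c1ccccc1NS(=O)(=O)c1cnc(O)nc1O`) is recorded at > 20000 nM as a limit of the assay and not as a number. Compound 4 (`O=C(NNC(=O)c1ccccc1NS(=O)(=O)c1cnc(O)nc1O)c1ccccc1F`) differs from compound 3 in one place ((2-fluorophenyl)carbonyl in place of 4-fluorophenyl on an amine nitrogen): (2-fluorophenyl)carbonyl stands in place of 4-fluorophenyl on an amine nitrogen. Going by the values given here, no measured step covers this change, so only a modest shift towards stronger inhibition in this assay is expected. The estimated step runs an at least 1.5-fold lower number from compound 3 to compound 4 (0.18 log units; that floor lies within the scatter) as a rough expectation. For compound 4 the expected value is 13000 nM with an estimated range from 4000 nM to 30000 nM overall.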

Compound 4, half-maximal inhibitory concentration: > 20000 nM
Compound 4: a limit, no number (the forecaster's own chance of this, stated with the estimate: 40%); middle value at least 1.5-fold (0.18 log units) from the limit.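

In this assay, going by these compounds alone, compound 3 and compound 4 both stand as limits and not as numbers; no step between them can be read. Going by these compounds, whether (2-fluorophenyl)carbonyl in place of 4-fluorophenyl changes activity at all remains open.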